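Exchanging the side chain of compound 3 for pyridin-3-yl

A few compounds are considered here, and "the series" means these few. Any claim that something is new, unique, unknown or untested is made for them only; others in the source may bear on it.

Measured in a functional assay on HeLa cells (Homo sapiens) for inhibition, with a stated time of 72 h; a higher number here means that more compound is needed for the effect, a lower number that less compound is needed:
- compound 1 `Clc1ccc(COc2ccc(CNCc3ccncc3)cc2)cc1`: 4000 nM
- compound 2 `COc1cc(OCc2cnc(Cl)c(Cl)c2)ccc1CNCc1ccncc1`: 400 nM
- compound 3 `COc1cc(CNCCSc2nnnn2C)ccc1OCc1ccc(Cl)nc1`: 86000 nM

Compound 3 has the highest number of the three, beyond the scatter from both others. Compound 4 `COc1cc(CNCc2cccnc2)ccc1OCc1ccc(Cl)nc1` is the next to be read: pyridin-3-yl in place of ((1-methyl-1H-tetrazol-5-yl)sulfanyl)methyl on a saturated chain carbon bound to an amine nitrogen. In words, pyridin-3-yl replaces ((1-methyl-1H-tetrazol-5-yl)sulfanyl)methyl on a saturated chain carbon bound to an amine nitrogen. For the measured compounds named here, no measured pair differs in one place only, so no direct precedent exists. Compound 1 (4000 nM) and compound 2 (400 nM) also carry a six-membered aromatic ring with 1 hetero atom there, so a lower number in this assay, beyond the scatter, is expected. The expected step is a 29-fold lower number from compound 3 to compound 4 (1.46 log units; beyond the scatter). For compound 4 the estimate is 3000 nM, with an expected range of 500 nM to 15000 nM.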

Compound 4, half-maximal effective concentration: 5000 nM
Compound 4: middle estimate off by 1.7-fold (0.22 log units), on the low side, within the range that was stated.
By their numbers in this assay, from the lowest: compound 2; then compounds 1 and 4 (each within the scatter of the next); then compound 3.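

For the compounds shown here, this is the first one-place step: in this assay the exchange gives a 17-fold lower number from compound 3 to compound 4 (1.24 log units; beyond the scatter), so the group on this saturated chain carbon bound to an amine nitrogen strongly affects the read-out. The step swaps both the ring and the sulfanyl link together, so this single pair cannot assign it to either one. No measurement at hand explains the step.

Open, on these data alone, is how phenyl would read in place of pyridin-3-yl. Also open, as far as these compounds go, is whether a 2-(phenylsulfanyl)ethyl chain would follow compound 3 or compound 4.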